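Replacing the end group of compound 1

The source may report more compounds than this note shows. Statements on the series, on what has been measured and on what is new or still open speak of the compounds shown alone.

In a functional assay on RS4-11 cells (Homo sapiens) for inhibition, read by CCK-8 assay, with a stated time of 48 h (on this read-out higher numbers stand for weaker inhibition and lower numbers for stronger inhibition), compound 1 `COc1ccc(NC(=O)NCCNS(=O)(=O)c2sccc2-c2ccc(C)cc2Oc2ccc(O)c(O)c2)cc1` gives 8200 nM and sits within the scatter of compound 3 `O=C(NCCNS(=O)(=O)c1ccc(-c2ccccc2Oc2ccc([N+](=O)[O-])c([N+](=O)[O-])c2)s1)Nc1ccc(Cl)cc1` at 6700 nM while compound 2 `O=C(NCCNS(=O)(=O)c1ccc(-c2ccccc2Oc2ccc([N+](=O)[O-])c([N+](=O)[O-])c2)s1)Nc1cc(Cl)cc(Cl)c1` at 2100 nM lies lower, beyond the scatter. From compound 1 to compound 4 `Cc1ccc(-c2ccsc2S(=O)(=O)NCCNC(=S)Nc2cccc([N+](=O)[O-])c2)c(Oc2ccc(O)c(O)c2)c1` the change is a group of 12 heavy atoms (7 carbon, 2 nitrogen, 2 oxygen, 1 sulfur; one six-membered aromatic ring of carbon only) in place of a group of 11 heavy atoms (8 carbon, 1 nitrogen, 2 oxygen; one six-membered aromatic ring of carbon only), on an amine nitrogen and the core stays the same. For the measured compounds named here, the only measured step of this sort, on an amide-type nitrogen, is a 3.2-fold higher number from compound 2 to compound 3 (0.50 log units; beyond the scatter) which is modest and comes from another pair, so it suggests a size but no direction. No step beyond the scatter is therefore expected in this assay here. The estimated step is a 1.4-fold lower number from compound 1 to compound 4 (0.14 log units; within the scatter) on present data. Compound 4 is estimated at 6000 nM with an expected range of 2000 nM to 18000 nM for now.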

Compound 4, half-maximal inhibitory concentration: 6100 nM
For compound 4 the middle estimate is 1.0-fold (0.01 log units) below the measured one; the measured number falls inside the stated range.
By their numbers in this assay, from the lowest: compound 2; then compounds 4, 3 and 1 (each within the scatter of the next).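

Working from a 1.3-fold lower number from compound 1 to compound 4 (0.13 log units; within the scatter) in this assay, the amine nitrogen of the core of compound 1 accepts the sulfur-containing group of 12 heavy atoms in place of (4-methoxyphenyl)carbamoyl with no change beyond the scatter. Unlike the earlier step on the dichlorophenyl series, this is a whole end-group exchange on the core of compound 1, and both end groups keep an aromatic carbon ring. No measured evidence is available to explain why these two end groups read alike.

Going by these compounds, whether that aromatic ring is needed stays open, since a carboxylic acid or a plain alkyl chain on this nitrogen would test it. Also open, on these data alone, is whether the 3,5-dichlorophenyl group of compound 2 would give a different number on the core of compound 1.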